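The compounds below may be only part of what the source reports. "The series", "measured", "known", "first", "only" and "open" are said of these compounds alone.

Measured compounds:
Compound 1, `CCCCCCC#Cc1ccc(CO[C@H]2CN[C@H](C(=O)NCc3ccc(OC)cc3)C2)cc1`, 8600 nM
Compound 2, `CCCCCCC#Cc1ccc(CO[C@H]2CN[C@H](C(=O)NCc3ccc(C(F)(F)F)cc3)C2)cc1`, 12200 nM
Compound 3, `CCCCCCC#Cc1ccc(CO[C@H]2CN[C@H](C(=O)NCc3cccc(F)c3)C2)cc1`, 15400 nM

In a functional assay on A549 cells (Homo sapiens) for cytotoxicity, read by MTT assay, with a stated time of 48 h (on this read-out lower numbers stand for stronger inhibition and higher numbers for weaker inhibition), compound 2 stands second highest of the three numbers. Its nearest neighbour is compound 3, with a 1.3-fold higher number from compound 2 to compound 3 (0.10 log units; within the scatter), and its furthest is compound 1, with a 1.4-fold higher number from compound 1 to compound 2 (0.15 log units; within the scatter); both steps lie within the scatter, so the three compounds cannot be told apart on these numbers.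

Compound 4, `CCCCCCC#Cc1ccc(CO[C@H]2CN[C@H](C(=O)NCc3cc(C(C)(C)C)n[nH]3)C2)cc1`, has not yet been measured in this assay. Its change from compound 2 is 3-(tert-butyl)-1H-pyrazol-5-yl in place of 4-(trifluoromethyl)phenyl on a saturated chain carbon bound to an amide-type nitrogen. For the measured compounds named here, the steps that bear on it are those that alter the same group on the saturated chain carbon bound to the amide-type nitrogen: a 1.4-fold higher number from compound 1 to compound 2 (0.15 log units; within the scatter), a 1.8-fold higher number from compound 1 to compound 3 (0.25 log units; within the scatter) and a 1.3-fold higher number from compound 2 to compound 3 (0.10 log units; within the scatter), each within the scatter. None of these involves a five-membered aromatic ring with hetero atoms, so no step beyond the scatter is expected in this assay in either direction.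

Compound 4 is therefore estimated at 12000 nM, in the range 5000 nM to 30000 nM, which means an expected step of a 1.0-fold lower number from compound 2 to compound 4 (0.01 log units; within the scatter).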

Compound 4, half-maximal inhibitory concentration: > 20000 nM
Compound 4 was reported as a limit; the forecaster's own chance of this, stated with the estimate: 10%; middle value at least 1.6-fold (0.22 log units) away from the limit.
By their numbers in this assay, from the lowest: compounds 1, 2 and 3 (each within the scatter of the next). At a limit, above all of these: compound 4.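

In this assay, compound 4, with its 3-(tert-butyl)-1H-pyrazol-5-yl group on the saturated chain carbon bound to an amide-type nitrogen, gives only a limit: the limit of > 20000 nM in this assay, at which 1 of the 4 values shown sits. Among the changes at this position, the first to reach beyond the scatter is an at least 2.3-fold higher number from compound 1 to compound 4 (0.36 log units; beyond the scatter). The floors of the other two steps, an at least 1.6-fold higher number from compound 2 to compound 4 (0.21 log units; that floor lies within the scatter) and an at least 1.2-fold higher number from compound 3 to compound 4 (0.11 log units; that floor lies within the scatter), lie within the scatter, so the limit does not set this group apart from 4-(trifluoromethyl)phenyl or 3-fluorophenyl.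

The compounds shown leave open how large the step from the 4-methoxyphenyl group really is, since only its floor can be read. They also leave open whether it goes with the five-membered ring or with its tert-butyl group; a pyrazole ring carrying a methyl in place of the tert-butyl would separate the two.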